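This account rests on a few compounds, and the source may have more. Where it says the series, first, only, none or still open, it means among the compounds named here.

Measured compounds:
Compound 1 `NC(=S)N/N=C/c1ccc(F)c2ccccc12`: in a toxicity assay on MRC5 cells (Homo sapiens) for cytotoxicity, read by MTT assay, with a stated time of 72 h (a lower number here means that less compound is needed, a higher number that more compound is needed for the effect), compound 1 reaches only a limit, > 200000 nM.
Compound 2 `NC(=S)N/N=C/c1ccc(OCc2ccccc2)c2ccccc12`: in this assay compound 2 gives 29000 nM.

Compound 2 holds the only number shown in this assay; the other value is a limit (the limit of > 200000 nM in this assay, at which 1 of the 2 values shown sits). Among the measured compounds shown here, the step of an at least 6.8-fold lower number from compound 1 to compound 2 (0.83 log units; beyond the scatter) is the only measured step, and it concerns a different change. Compound 3 `NC(=S)N/N=C/c1ccc(OCC2CCCCC2)c2ccccc12` differs from compound 2 by cyclohexyl in place of phenyl on a saturated chain carbon bound to an oxygen on an aromatic ring. For the measured compounds named here, no measured step bears on this change, since the step from compound 1 to compound 2 alters the group on the aromatic carbon rather than the ring at the end of the chain. In this assay compound 3 is therefore expected to show a step of a 1.2-fold lower number from compound 2 to compound 3 (0.06 log units; within the scatter) from compound 2, no more than the scatter. The estimate for compound 3 is 25000 nM, with a range from 8000 nM to 80000 nM.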

Compound 3, half-maximal effective concentration: 28900 nM
Estimate against measurement, compound 3: 1.2-fold (0.06 log units) below, within the range that was stated.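

In this assay, putting a saturated ring in place of the aromatic one at the end of the chain gives a 1.0-fold lower number from compound 2 to compound 3 (0.00 log units; within the scatter), so phenyl and cyclohexyl on a saturated chain carbon bound to an oxygen on an aromatic ring cannot be told apart here. The earlier step showed only one replacement of fluoro, and an at least 6.9-fold lower number from compound 1 to compound 3 (0.84 log units; beyond the scatter) now shows a second group in that place also giving a lower number, beyond the scatter. That step can be read only as a bound, because compound 1 stands at a limit: the limit of > 200000 nM in this assay, at which 1 of the 3 values shown sits.

The compounds shown leave open whether the number would hold with something other than a six-membered carbon ring at the end of the chain, such as an amine or a carboxylic acid. They also leave open the effect of a longer chain carrying the same rings.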